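The source may hold more compounds than are shown below. What is called first, only, known or untested is meant among the compounds shown, and "the series" means these compounds.

Compound 3 `COc1ccc(/C=C/C(=O)c2ccc(OC)c3c2OC(C)(C)C=C3)cc1OCCO` is the only one of the three measured compounds that gives a number in a functional assay on A-375 cells (Homo sapiens) for cytotoxicity, read by MTT assay (a higher number here means a weaker inhibitor, a lower number a stronger inhibitor), where compound 3 gives 9600 nM. Compound 1 `COc1ccc(/C=C/C(=O)c2ccc(OC)c3c2OC(C)(C)C=C3)cc1OCC=C(C)C` sits at a limit of this assay, > 10000 nM. Compound 2 `C#CCOc1cc(/C=C/C(=O)c2ccc(OC)c3c2OC(C)(C)C=C3)ccc1OC` likewise sits at a limit, > 10000 nM. Compound 4 `C=CC(=O)Oc1cc(/C=C/C(=O)c2ccc(OC)c3c2OC(C)(C)C=C3)ccc1OC` differs from compound 3 in one place: vinylcarbonyl in place of 2-hydroxyethyl on an oxygen on an aromatic ring. The measured steps that bear on this change also swap the group carried on the aromatic oxygen: an at least 1.0-fold lower number from compound 1 to compound 3 (0.01 log units; that floor lies within the scatter) and an at least 1.0-fold lower number from compound 2 to compound 3 (0.01 log units; that floor lies within the scatter), and the limit of > 10000 nM in this assay, at which 2 of the 3 values shown sit, leaves their true size unreadable. Nothing here points to a gain beyond the scatter, so the expected step is a 1.1-fold lower number from compound 3 to compound 4 (0.03 log units; within the scatter). Compound 4 is estimated at 9000 nM, between 3000 nM and 30000 nM.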

Compound 4, half-maximal inhibitory concentration: 390 nM
Estimate against measurement, compound 4: 23-fold (1.36 log units) above, and the stated range ends above it.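

Within the data shown here, on an oxygen on an aromatic ring, the group carried there can matter a great deal in this assay: vinylcarbonyl in place of 2-hydroxyethyl gives a 25-fold lower number from compound 3 to compound 4 (1.39 log units; beyond the scatter), the first step at this position that is beyond the scatter. Vinylcarbonyl also gives an at least 25-fold lower number from compound 2 to compound 4 (1.40 log units; beyond the scatter) and an at least 25-fold lower number from compound 1 to compound 4 (1.40 log units; beyond the scatter). These last two sizes are only floors, because compound 1 and compound 2 each sit at a limit: the limit of > 10000 nM in this assay, at which 2 of the 4 values shown sit.

Still open, on these data alone, is whether this gain needs the carbon-carbon double bond of vinylcarbonyl, or whether an acetyl group on the same oxygen would also give it.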